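Indazole for benzofuran on the sulfonyl sulfur

A few compounds are considered here, and "the series" means these few. Any claim that something is new, unique, unknown or untested is made for them only; others in the source may bear on it.

Measured so far:
compound 1 `CCN(Cc1ccccc1)C(=O)C1CCN(S(=O)(=O)c2ccc(C(F)(F)F)nc2)CC1`, "not determined" (no result reported)
compound 2 `CCN(Cc1ccccc1)C(=O)C1CCN(S(=O)(=O)c2ccc3occc3c2)CC1`, 80%
compound 3 `CCN(C(=O)C1CCN(S(=O)(=O)c2ccc3occc3c2)CC1)[C@H](C)c1ccccc1`, 80%

Read-out is a functional assay on CHO cells for positive allosteric modulation of muscarinic acetylcholine receptor M5 (Homo sapiens), read by calcium flux; a lower number here means a smaller maximal response, a higher number a larger maximal response. Compound 3 stands level with compound 2 at the digits shown; the only measured step, no change at the digits printed from compound 2 to compound 3 (within the scatter), sits on the amide side and lies within the scatter. Compound 1 carries no result.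

Compound 4 `CCN(C(=O)C1CCN(S(=O)(=O)c2ccc3[nH]ncc3c2)CC1)[C@H](C)c1ccccc1` differs from compound 3 by 1H-indazol-5-yl in place of 1-benzofuran-5-yl on a sulfonyl sulfur. Among the measured compounds shown here, no measured step touches the group on the sulfonyl sulfur, so the step from compound 3 is expected to stay within the scatter: a number 2 percentage points lower from compound 3 to compound 4 (within the scatter). For compound 4 the estimate is 78%, with a range from 60% to 95%.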

Compound 4, largest response reached (reported as percent of maximum), in percent of the reference or control that the assay uses: 86%
The estimate for compound 4 lay 8 percentage points below the measured number; low and high end bracket the measured number.
By their numbers in this assay, from the lowest: compounds 2, 3 and 4 (each within the scatter of the next).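

In this assay, among the compounds shown here, 1H-indazol-5-yl in place of 1-benzofuran-5-yl on the sulfonyl sulfur gives a number 6 percentage points higher from compound 3 to compound 4 (within the scatter), the first reading of a change at this position. The swap brings a hydrogen-bond donor into the group without a step beyond the scatter, so this position accepts both bicyclic groups in this series. No supporting data bear on this result.

Still open, as far as these compounds go, is whether an indole or a benzimidazole on the sulfonyl sulfur would hold the maximal response. Also open, from the compounds shown here alone, is whether the indazole step carries over to the amide without the added methyl.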